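From 2-Methoxyethyl to Ethyl: A Stability Question

This account rests on a few compounds, and the source may have more. Where it says the series, first, only, none or still open, it means among the compounds named here.

- compound 1 `CCC(O)Cc1cc(-c2ccnc3[nH]nc(C(F)(F)F)c23)cc(C2(C#N)CC2)c1`: 17%
- compound 2 `COCCc1cc(-c2ccnc3[nH]nc(C(F)(F)F)c23)cc(C2(C#N)CC2)c1`: 90%

In an ADME assay on S9 fraction from liver (Rattus norvegicus) for metabolic stability, read by LC-MS, using NADPH, with a stated time of 60 min, tested at 10 uM (on this read-out lower numbers stand for a less stable compound and higher numbers for a more stable compound), compound 2 holds the higher of the two numbers, at 90%. Compound 3 `CCc1cc(-c2ccnc3[nH]nc(C(F)(F)F)c23)cc(C2(C#N)CC2)c1` differs from it in one place: hydrogen in place of methoxy on a saturated chain carbon, two bonds along the chain from an aromatic carbon. This is hydrogen in place of methoxy on a saturated chain carbon, two bonds along the chain from an aromatic carbon, so 2-methoxyethyl becomes ethyl.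

For the measured compounds named here, only one measured step bears on this change: a number 73 percentage points higher from compound 1 to compound 2 (beyond the scatter). That large step, beyond the usual scatter, shows that changing this side chain can move the number a long way. However, it involves a different group, so it does not settle the direction here. With compound 2 at 90%, little room remains upward, so a moderate fall is expected, smaller than that step. The expected change is a number 20 percentage points lower from compound 2 to compound 3 (beyond the scatter). For compound 3 the estimated value is 70%, with an expected range of 40% to 95%.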

Compound 3, percent of the compound remaining: 78%
Estimate against measurement, compound 3: 8 percentage points below; the range from low to high includes it.
By their numbers in this assay, from the lowest: compound 1; then compound 3; then compound 2.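

In this assay, the plain ethyl group gives a number 12 percentage points lower from compound 2 to compound 3 (beyond the scatter) and so shows that a real but modest part of the number of compound 2 is lost when the methoxy leaves this saturated chain carbon. Compound 3 also gives a number 61 percentage points higher from compound 1 to compound 3 (beyond the scatter) and this large step, much bigger than the loss of methoxy, shows that a high number at this position does not depend on the methoxy; among these three compounds, only compound 1, with its 1-hydroxypropyl group, gives a low number. Nothing measured here explains why the numbers differ.

From the compounds shown here alone, it remains open how a longer chain, such as propyl, would compare with ethyl at this position. An amine or a carboxylic acid on the same chain carbon also remains an untested question within the compounds shown.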